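A few compounds are considered here, and "the series" means these few. Any claim that something is new, unique, unknown or untested is made for them only; others in the source may bear on it.

Measured in a toxicity assay on CHO-K1 cells (Cricetulus griseus) for cytotoxicity, read by MTT assay, with a stated time of 48 h; on this read-out higher numbers stand for weaker inhibition and lower numbers for stronger inhibition:

- Compound 1 `COc1cc(/C=C/C(=O)/C=C(/C=C/c2ccc(O)c(OC)c2)NCCO)ccc1O`: 87500 nM
- Compound 2 `O=C(/C=C(/C=C/c1ccc(O)cc1)NCCCO)/C=C/c1ccc(O)cc1`: 39100 nM

Compound 2 has the lower number of the two, and its gap to compound 1 lies beyond the scatter. Compound 3 `COCCNC(=C\C(=O)/C=C/c1ccc(O)cc1)/C=C/c1ccc(O)cc1`, not yet measured in this assay, departs from compound 2 by one change: methoxy in place of hydroxymethyl on a saturated chain carbon, two bonds along the chain from an amine nitrogen. This puts methoxy in place of hydroxymethyl on a saturated chain carbon, two bonds along the chain from an amine nitrogen. For the measured compounds named here, no measured pair shows this change, so the expected 1.1-fold higher number from compound 2 to compound 3 (0.03 log units; within the scatter) is none beyond the scatter, in either direction. For compound 3 the estimated value is 42000 nM, with an expected range from 18000 nM to 95000 nM.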

Compound 3, half-maximal inhibitory concentration: 34900 nM
Estimate against measurement, compound 3: 1.2-fold (0.08 log units) above; measured number inside the range.
By their numbers in this assay, from the lowest: compounds 3 and 2 (each within the scatter of the next); then compound 1.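

In this assay, placing methoxy in place of hydroxymethyl on a saturated chain carbon, two bonds along the chain from an amine nitrogen, gives a 1.1-fold lower number from compound 2 to compound 3 (0.05 log units; within the scatter) on the shared core. At this position, then, exchanging a group that counts a hydrogen-bond donor for one that counts none produces no difference beyond the scatter. No evidence at hand explains this outcome. Going by these compounds, whether an amine, a carboxylic acid or a longer chain at this place would shift the number beyond the scatter stays open. Also open, on these data alone, is whether the same exchange would read alike on the core of compound 1.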